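The compounds below may be only part of what the source reports. "The series", "measured", "known", "first", "only" and "open" are said of these compounds alone.

- compound 1 (`CN1C/C(=C\c2ccc(C(F)(F)F)cc2)C(=O)/C(=C/c2cccc([N+](=O)[O-])c2)C1`): 12400 nM
- compound 2 (`CN1C/C(=C\c2ccc(F)cc2)C(=O)/C(=C/c2ccc(C#N)cc2)C1`): 20900 nM

In an ADME assay on L02 cells (Homo sapiens) for cytotoxicity, read by MTT assay, with a stated time of 24 h (a lower number here means a stronger inhibitor, a higher number a weaker inhibitor), compound 2 stands at 20900 nM and lies within the usual scatter of compound 1, so the two values cannot be told apart. Compound 3 (`CN1C/C(=C\c2ccc(C#N)cc2)C(=O)/C(=C/c2ccc(Cl)cc2Cl)C1`) differs from compound 2 by 2,4-dichlorophenyl in place of 4-fluorophenyl on a double-bonded chain carbon bound to a double-bonded ring carbon and awaits measurement. For the measured compounds named here, no measured pair shows this change, so only a small step toward a lower number is expected in this assay, hardly beyond the scatter. The expected step is modest (a 1.9-fold lower number from compound 2 to compound 3 (0.28 log units; within the scatter)). For compound 3 the estimated value is 11000 nM (expected range 4500 nM to 28000 nM).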

Compound 3, half-maximal inhibitory concentration: 10800 nM
Estimate against measurement, compound 3: 1.0-fold (0.01 log units) above; the measured number falls inside the stated range.
By their numbers in this assay, from the lowest: compounds 3, 1 and 2 (each within the scatter of the next).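

In this assay, 2,4-dichlorophenyl in place of 4-fluorophenyl on a double-bonded chain carbon bound to a double-bonded ring carbon gives a step within the scatter (a 1.9-fold lower number from compound 2 to compound 3 (0.29 log units; within the scatter)). For the compounds shown here, this is the first reading of a single change at this place, and it shows that one extra heavy atom and chlorine in place of fluorine leave the number indistinguishable. No measured data here bear on this result. The compounds shown leave open whether an amine or a carboxylic acid at this place would move the number beyond the scatter.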